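Hydroxy to Amino on a Biphenyl Diol Core

The source may hold more compounds than are shown below. What is called first, only, known or untested is meant among the compounds shown, and "the series" means these compounds.

Measured compounds:
Compound 1, `Oc1ccc(-c2cccc(O)c2)cc1`: 31 ug/mL
Compound 2, `Nc1ccc(-c2cccc(O)c2)cc1`: 55 ug/mL
Compound 3, `COc1ccc(-c2ccc(O)cc2)cc1OC`: > 100 ug/mL

In an ADME assay on HEK293 cells (Homo sapiens) for cytotoxicity, read by MTT assay, with a stated time of 3 days (a lower number here means a stronger inhibitor, a higher number a weaker inhibitor), compound 1 gives 31 ug/mL. Compound 2, which carries amino in place of hydroxy on an aromatic carbon, gives 55 ug/mL in this assay. Among the compounds with values here, the step of a 1.8-fold higher number from compound 1 to compound 2 (0.25 log units; within the scatter) is the only measured step here. For compound 3 the result in this assay is a limit of the assay and not a number, > 100 ug/mL, as stated under (the limit of > 100 ug/mL in this assay, at which 1 of the 3 values shown sits). How the core of compound 3 differs from the core of compound 1 is not broken down here.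

Compound 4, `COc1ccc(-c2ccc(N)cc2)cc1OC`, has not yet been measured in this assay. It differs from compound 3 by amino in place of hydroxy on an aromatic carbon. Within the data shown here, this is the same kind of change as the one from compound 1 to compound 2; around the place the two differ only in that the group is para to a large group in compound 4, and para to a group of 7 heavy atoms in compound 2.

Compound 4 is expected to give 150 ug/mL in this assay. That expectation rests on the step of a 1.8-fold higher number from compound 1 to compound 2 (0.25 log units; within the scatter), which was within the scatter, and on compound 3 already sitting at the limit described under (the limit of > 100 ug/mL in this assay, at which 1 of the 3 values shown sits). The estimated step is a step that the limit leaves unreadable from compound 3 to compound 4, with a value most likely again reported only as a limit. Compound 4 is estimated to lie between 70 ug/mL and 400 ug/mL.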

Compound 4, half-maximal inhibitory concentration: 23 ug/mL
Estimate against measurement, compound 4: 6.5-fold (0.81 log units) above, outside the stated range (below it).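

In this assay, as far as these compounds go, amino in place of hydroxy gives an at least 4.3-fold lower number from compound 3 to compound 4 (0.63 log units; beyond the scatter), so on this core the change has a clear effect, and it does not carry over unchanged from the core of compound 1: the same change on two cores in this assay, a 1.8-fold higher number (0.25 log units; within the scatter) from compound 1 to compound 2 and an at least 4.3-fold lower number (0.63 log units; beyond the scatter) from compound 3 to compound 4, at least 7.7-fold (0.88 log units) apart, beyond the scatter of two such steps The size of the new step stays open at one end, since compound 3 has only a limit of the assay, > 100 ug/mL, and not a number: the limit of > 100 ug/mL in this assay, at which 1 of the 4 values shown sits. The two pairs show that the outcome of this change depends on the core it sits on, but they do not show which difference between the two cores accounts for the gap, how large the step on the core of compound 3 really is, or how the change would behave on any third core.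

The compounds shown leave open whether the methoxy groups of compounds 3 and 4 matter to the result, as a core with a single methoxy group or with ethoxy groups in their place would test. They also leave open how a methylamino or an acetamido group would compare with the amino group of compound 4 on the same core.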